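Enlarging the amino group of compound 3

A few compounds are considered here, and "the series" means these few. Any claim that something is new, unique, unknown or untested is made for them only; others in the source may bear on it.

In a functional assay on the whole organism for positive allosteric modulation, with Mus musculus as the target (a lower number here means that less compound is needed, a higher number that more compound is needed for the effect), compound 3 `CCC(=O)N(c1ccc(Cl)c(Cl)c1)C1CCCC1N` gives 0.02 mg/kg, the lowest number shown. Compound 2 `CCC(=O)N(c1cccc(Br)c1)C1CCCC1N(C)C` gives 0.1 mg/kg, a gap from compound 3 that lies beyond the scatter. Compound 1 `CCC(=O)N(c1c(F)c(F)c(F)c(F)c1F)C1CCCC1N(C)C` reaches a limit of the assay, > 50 mg/kg.

Compound 4 `CCC(=O)N(c1ccc(Cl)c(Cl)c1)C1CCCC1N(C)CCN(C)C` carries (2-(dimethylamino)ethyl)(methyl)amino in place of amino on a saturated ring carbon. For the measured compounds named here, no measured pair tests this exchange. With compound 3 at 0.02 mg/kg, the lowest number shown, a move to a higher number seems the more likely direction. The expected change is a 150-fold higher number from compound 3 to compound 4 (2.18 log units; beyond the scatter), beyond the scatter. For compound 4 the estimated value is 3 mg/kg, with an expected range of 0.2 mg/kg to 40 mg/kg.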

Compound 4, dose for half-maximal effect: 0.8 mg/kg
For compound 4 the middle estimate is 3.8-fold (0.57 log units) above the measured one; low and high end bracket the measured number.
By their numbers in this assay, from the lowest: compound 3; then compound 2; then compound 4. At a limit, above all of these: compound 1.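

In this assay, exchanging amino for (2-(dimethylamino)ethyl)(methyl)amino on the saturated ring carbon gives the first step read at this position, and it is large: a 40-fold higher number from compound 3 to compound 4 (1.60 log units; beyond the scatter). Even so, compound 4 gives a measured number, 0.8 mg/kg, rather than a limit, so the effect survives this much larger group. Nothing shown bears on the cause of this step.

Open, from the compounds shown here alone, is whether a smaller methylamino or dimethylamino group on the core of compound 3 stays closer to compound 3 or compound 4. Also open, going by these compounds, is how a morpholine ring or a carboxylic acid at the end of the chain would compare.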